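Pyrazolyl nucleoside series: ethyl ester in place of acid

A few compounds are considered here, and "the series" means these few. Any claim that something is new, unique, unknown or untested is made for them only; others in the source may bear on it.

Measured compounds in an in vitro assay on HEK293 cells for displacement of a labelled ligand from adenosine receptor A2b (Homo sapiens); a lower number here means a stronger inhibitor, a higher number a weaker inhibitor:
Compound 1 `CCOC(=O)c1cnn(-c2nc(NC3CCCCC3)c3ncn([C@@H]4O[C@H](CO)[C@@H](O)[C@H]4O)c3n2)c1` gives > 6000 nM, which is a limit of the assay.
Compound 2 `Cc1ccc(Nc2nc(-n3cc(CO)cn3)nc3c2ncn3[C@@H]2O[C@H](CO)[C@@H](O)[C@H]2O)cc1` gives > 6000 nM, which is a limit of the assay.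
Compound 3 `O=C(O)c1cnn(-c2nc(NC34CCC(CC3)C4)c3ncn([C@@H]4O[C@H](CO)[C@@H](O)[C@H]4O)c3n2)c1` gives > 6000 nM, which is a limit of the assay.

Compound 3 therefore stands at the limit of this assay, and no number is known for it. For the measured compounds named here, the same holds for the two other measured compounds: the limit of > 6000 nM in this assay, at which 3 of the 3 values shown sit, so nothing in the set so far distinguishes one compound from another, and no step between measured compounds can be read.

Compound 4 `CCOC(=O)c1cnn(-c2nc(NC34CCC(CC3)C4)c3ncn([C@@H]4O[C@H](CO)[C@@H](O)[C@H]4O)c3n2)c1` is not yet measured. It differs from compound 3 in one place: ethyl in place of hydrogen on an oxygen next to a carbonyl group. Compound 1 carries the same ethoxycarbonyl group on the same pyrazolyl ring, together with a different amine substituent on the shared core, and sits at the limit; compound 3, with the carboxy group, sits at the limit as well. Nothing measured in this series points to a gain from the change.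

On this basis compound 4 is expected to give 9000 nM (range 3000 nM to 30000 nM) in this assay, meaning the estimated step that the limit leaves unreadable from compound 3 to compound 4 is no movement beyond the scatter; most likely the assay will again report only a limit.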

Compound 4, inhibition constant: > 6000 nM
Compound 4 was reported as a limit; the forecaster's own chance of this, stated with the estimate: 80%; the middle value does not contradict the limit.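

In this assay compound 4 gives > 6000 nM, which is a limit of the assay. Neither the step from compound 3 to compound 4 nor the step from compound 1 to compound 4 can be read, because every value sits at the same limit: the limit of > 6000 nM in this assay, at which 4 of the 4 values shown sit. The compounds shown leave open whether carboxy or ethoxycarbonyl, or either amine substituent, makes any difference in this assay.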